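A few compounds are considered here, and "the series" means these few. Any claim that something is new, unique, unknown or untested is made for them only; others in the source may bear on it.

Measured so far in an assay for inhibition of Fatty-acid amide hydrolase 1 (Rattus norvegicus); a lower number here means a stronger inhibitor, a higher number a weaker inhibitor:
- compound 1, `O=C(O)c1ccc(-c2cnc(C(=O)CCc3ccc(-c4ccccc4)cc3)o2)nc1`, 14 nM
- compound 2, `O=C(O)c1ccc(-c2cnc(C(=O)CCc3ccc(Oc4ccccc4)cc3)o2)nc1`, 33 nM

Compound 2 stands at the higher of the two numbers in this assay; its nearest neighbour is compound 1, and the step of a 2.4-fold higher number from compound 1 to compound 2 (0.37 log units; beyond the scatter) is modest but beyond the scatter.

Compound 3, `NC(=O)c1cnc(C(=O)CCc2ccc(Oc3ccccc3)cc2)o1`, differs from compound 2 in one place: carbamoyl in place of 5-carboxypyridin-2-yl on an aromatic carbon. Among the measured compounds shown here, the one measured step, from compound 1 to compound 2, concerns the other end of the molecule and does not bear on this change; no measured pair shows what removing the 5-carboxypyridin-2-yl group and leaving a carbamoyl in its place does in this assay. The change takes away a large part of the structure, so the expectation for compound 3 is a weaker number than compound 2, with wide uncertainty, as the step of a 3.6-fold higher number from compound 2 to compound 3 (0.56 log units; beyond the scatter) expresses. Compound 3 is therefore estimated at 120 nM in this assay, within a range of 15 nM to 900 nM.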

Compound 3, inhibition constant: 6.6 nM
The estimate for compound 3 lay 18-fold (1.26 log units) above the measured number, outside the stated range (below it).
By their numbers in this assay, from the lowest: compound 3; then compound 1; then compound 2.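

At the aromatic carbon next to the ring oxygen, the 5-carboxypyridin-2-yl group is not needed for a low number in this assay: replacing it with carbamoyl gives a 5.0-fold lower number from compound 2 to compound 3 (0.70 log units; beyond the scatter) and the step is modest. In this single pair, the group with fewer heavy atoms and no ring gives the lower number, so the six-membered aromatic ring of the leaving group is dispensable at this position for compounds carrying the phenoxy group. No supporting data are available to account for the step.

As far as these compounds go, it remains open whether the carbamoyl itself matters, or whether a nitrile, a carboxylic acid or a bare hydrogen at the same carbon would give a similar number. From the compounds shown here alone, it is also open whether carbamoyl at this position gives a comparable step with the phenyl group of compound 1 in place of phenoxy.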